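Dropping the Amino Group from an Indole Compound Measured for Aromatase Inhibition

The source may hold more compounds than are shown below. What is called first, only, known or untested is meant among the compounds shown, and "the series" means these compounds.

Measured so far:
Compound 1 `Cc1ccc(-c2cc3ccccc3[nH]2)cc1` gives 9.33% in an assay on isolated protein for inhibition of Aromatase (Homo sapiens), read by fluorescence, using NADPH, with a stated time of 30 min, tested at 50 uM; a lower number here means less inhibition, a higher number more inhibition at the concentration tested (going by the name of the read-out).
Compound 2 `Cn1c(-c2ccc(Cl)c(Cl)c2)cc2cc(N)ccc21` gives 42% in this assay.
Compound 3 `COc1cc(OC)cc(-c2cc3ccccc3[nH]2)c1` gives 9.18% in this assay.

Of the three compounds measured, compound 2 stands highest: its number lies well beyond the usual scatter above both compound 1 and compound 3, whose two numbers sit within the scatter of each other and cannot be ordered. Compound 2 is also the only one of the three that carries a methyl on the ring nitrogen, a dichlorophenyl group and an amino group, so the measured numbers alone cannot tell which of these features matters.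

Compound 4 `Cn1c(-c2ccc(Cl)c(Cl)c2)cc2ccccc21` has not yet been measured. It differs from compound 2 in one place: hydrogen in place of amino on an aromatic carbon. Among the compounds with values here, no measured pair shows this exact change, so the size of its effect is unknown. In this assay the step is expected to be downward, of moderate size, since the compounds lacking the amino group measured so far give low numbers, though they differ in other places too; the expected step is a number 17 percentage points lower from compound 2 to compound 4 (beyond the scatter). For compound 4 the estimate is 25%, with a likely range from 5% to 45%.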

Compound 4, a percentage reported as inhibition, at one concentration (the size of the read-out at that concentration, not a potency): 20%
Compound 4: middle estimate off by 5 percentage points, on the high side; measured number inside the range.
By their numbers in this assay, from the lowest: compounds 3 and 1 (each within the scatter of the next); then compound 4; then compound 2.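

Within the data shown here, this pair is the first to isolate the amino group: the methyl on the ring nitrogen and the dichlorophenyl group stay the same, and putting hydrogen in place of amino on the aromatic carbon gives a number 22 percentage points lower from compound 2 to compound 4 (beyond the scatter) in this assay. The amino group at this place on the six-membered aromatic ring therefore accounts for part of the number seen for compound 2, yet compound 4 still gives 20%, so within this pair the inhibition does not disappear with the amino group. No measurement shown explains how this change alters the number.

The compounds shown leave open whether a hydroxyl group, a dimethylamino group or a carboxylic acid at this same place would match the amino group, fall to the level of hydrogen or go beyond either. Among these compounds, they also leave open what the methyl on the ring nitrogen and the dichlorophenyl group each contribute, since no pair of measured compounds differs in only one of those features.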